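Diaryl ureas on a shared core: fluoro to chloro

The source may report more compounds than this note shows. Statements on the series, on what has been measured and on what is new or still open speak of the compounds shown alone.

Measured so far:
compound 1, `Cc1cccc(NC(=O)Nc2ccc(Oc3nc(C)cc(C)n3)cc2)c1`: "not determined" (no result reported)
compound 2, `Cc1cc(C)nc(Oc2ccc(NC(=O)Nc3ccc(F)cc3)cc2)n1`: > 50000 nM

The series is read in a functional assay on MCF7 cells (Homo sapiens) for cytotoxicity, read by MTT assay, with a stated time of 3 days; on this read-out higher numbers stand for weaker inhibition and lower numbers for stronger inhibition. For compound 1 no result is recorded, so it carries only the entry "not determined" (no result reported). For compound 2 the assay reports a limit and not a number, > 50000 nM. On the numbers shown, compound 2 therefore stands at the limit of the assay, which is where one of the two values sits (the limit of > 50000 nM in this assay, at which 1 of the 2 values shown sits); nothing places it on a scale against compound 1.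

Compound 3, `Cc1cc(C)nc(Oc2ccc(NC(=O)Nc3ccc(Cl)cc3)cc2)n1`, differs from compound 2 by chloro in place of fluoro on an aromatic carbon of a six-membered aromatic ring of carbon only. Within the data shown here, no measured pair with this change exists here, so no step size can be taken from data. Given compound 2 at the limit > 50000 nM, the shift from fluoro to chloro is expected to stay within the usual scatter, with no directional change beyond it. Compound 3 is therefore expected, in this assay, to give about 60000 nM, between 20000 nM and 200000 nM, an expected step that the limit leaves unreadable from compound 2 to compound 3, and most likely again only a limit.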

Compound 3, half-maximal inhibitory concentration: > 50000 nM
Compound 3 ended at the assay's limit (the forecaster's own chance of this, stated with the estimate: 70%); the middle value is on the limit's open side.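

Compound 2 gives > 50000 nM as a limit in this assay and not a number. Among these compounds, compound 3 gives > 50000 nM as a limit too, so no step between these two compounds can be read. On these data alone, whether chloro in place of fluoro changes cytotoxicity at all remains open.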